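A few compounds are considered here, and "the series" means these few. Any claim that something is new, unique, unknown or untested is made for them only; others in the source may bear on it.

Of the compounds shown here, two have been measured. Compound 1 `Cc1cnc(Nc2ccc(S(C)(=O)=O)cc2)nc1Nc1nc2ccc(Cl)cc2s1` and compound 2 `NS(=O)(=O)c1ccc(Nc2ncc(F)c(Nc3nc4ccc(Cl)cc4s3)n2)cc1` share a core built around a central ring that carries two amine linkers. In a functional assay on HeLa cells (Homo sapiens) for antiproliferative activity, read by MTT assay, with a stated time of 48 h (on this read-out higher numbers stand for weaker inhibition and lower numbers for stronger inhibition), compound 1 gives 4180 nM, and in this assay compound 2 gives 8770 nM. Of these two numbers, the value of compound 1 is the lower one, and the gap between compound 1 and compound 2 lies beyond the usual scatter of the measurement, so compound 1 stands as the stronger inhibitor of the pair.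

Compound 3 `Cc1cnc(Nc2ccc(S(C)(=O)=O)cc2)nc1Nc1nc2ccc(F)cc2s1` has not yet been measured. It differs from compound 1 in a single place: fluoro in place of chloro on an aromatic carbon. No step of this kind has been measured among these compounds, so there is no direct guide to its size. The expectation is a modest weakening from compound 1, an estimated step of a 1.4-fold higher number from compound 1 to compound 3 (0.16 log units; within the scatter), which may well fall within the scatter. Compound 3 is therefore expected to give about 6000 nM in this assay, with a likely range from 2500 nM to 15000 nM.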

Compound 3, half-maximal inhibitory concentration: > 50000 nM
Compound 3 ended at the assay's limit; the forecaster's own chance of this, stated with the estimate: 5%; middle value at least 8.3-fold (0.92 log units) from the limit.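

On the six-membered aromatic ring of carbon only, part of a fused system of two rings, this swap of one atom is far from neutral: fluoro in place of chloro gives an at least 11-fold higher number from compound 1 to compound 3 (1.07 log units; beyond the scatter) in this assay. One heavy atom replaces one heavy atom and the count of hydrogen-bond donors and acceptors stays the same, yet the first two compounds gave no sign that this position could matter so much. The value of compound 3 is a limit of the assay and not a number, so the step has a floor but no measured size: the limit of > 50000 nM in this assay, at which 1 of the 3 values shown sits.

As far as these compounds go, what bromo, methyl or methoxy would do at this place stays open, and with it whether chloro is special here or fluoro is the exception. Also open, from the compounds shown here alone, is whether the same swap would carry the same weight in compound 2.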